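The source may hold more compounds than are shown below. What is called first, only, known or untested is meant among the compounds shown, and "the series" means these compounds.

Measured in a functional assay on PC-3 cells (Homo sapiens) for antiproliferative activity, read by MTT assay, with a stated time of 48 h; a lower number here means a stronger inhibitor, a higher number a weaker inhibitor:
compound 1 `O=C(NO)c1ccc(/C=C/c2ccc(O)cc2)o1`: 21800 nM
compound 2 `O=C(/C=C/c1ccc(/C=C/C(=O)c2cccc(Cl)c2)o1)NO`: 9600 nM
compound 3 `O=C(NO)c1ccc(/C=C/c2ccccc2O)o1`: 91300 nM

Among these three, compound 2 gives the lowest number, 9600 nM, which makes it the strongest inhibitor of the set in this assay. Compound 1 sits nearest to it and compound 3 furthest, and both gaps lie beyond the usual scatter of repeated measurements.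

The next compound to be tested, compound 4 `Cc1ccc(C(=O)/C=C/c2ccc(/C=C/C(=O)NO)o2)cc1`, differs from compound 2 in one place: 4-methylphenyl in place of 3-chlorophenyl on a carbonyl carbon. Put simply, 4-methylphenyl stands in place of 3-chlorophenyl on a carbonyl carbon, and the rest of the molecule stays the same.

Going by the values given here, no two measured compounds here differ in one place only, and the effect of such an exchange has no direct measure. The expectation starts from compound 2 at 9600 nM, with no firm ground for either direction. A step within the scatter is the expected outcome in this assay. The estimated change is a 1.0-fold higher number from compound 2 to compound 4 (0.02 log units; within the scatter). Compound 4 is expected at 10000 nM, with an estimated range from 4000 nM to 25000 nM.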

Compound 4, half-maximal inhibitory concentration: 16000 nM
Compound 4: middle estimate off by 1.6-fold (0.20 log units), on the low side; low and high end bracket the measured number.
By their numbers in this assay, from the lowest: compounds 2, 4 and 1 (each within the scatter of the next, the first and the last beyond it); then compound 3.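

In this assay, going by these compounds alone, this pair gives the first direct reading at this position, the aromatic ring on the carbonyl carbon, and the exchange of 3-chlorophenyl for 4-methylphenyl is a 1.7-fold higher number from compound 2 to compound 4 (0.22 log units; within the scatter). The two groups have the same count of heavy atoms, each is one six-membered aromatic ring of carbon only, and neither has hydrogen-bond donors or acceptors, so this assay does not separate these two substituted rings at this carbonyl carbon. Nothing available here ties this outcome to any property of either group.

The exchange alters both the substituent and its printed ring position, so 4-chlorophenyl or 3-methylphenyl would be needed to read those two parts apart, and plain phenyl would show what either substituent adds. As far as these compounds go, it also remains open whether a more different group on this carbonyl carbon, such as a phenyl ring carrying a carboxylic acid or an amine, would produce a step beyond the scatter.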